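From Fluoro to Formyl on a Shared Core

This account rests on a few compounds, and the source may have more. Where it says the series, first, only, none or still open, it means among the compounds named here.

In a functional assay on HepG2 cells (Homo sapiens) for inhibition, read by MTT assay, with a stated time of 48 h (a higher number here means a weaker inhibitor, a lower number a stronger inhibitor), compound 1 (`COc1cccc(/C=C/C(=O)c2cc(OC)c(OC)c(OC)c2)c1O`) gives 13500 nM while compound 2 (`COc1cc(C(=O)/C=C/c2ccc(F)cc2)cc(OC)c1OC`) gives 22000 nM and these two numbers lie within the scatter of each other. Compound 3 (`COc1cc(C(=O)/C=C/c2ccc(C=O)cc2)cc(OC)c1OC`) carries a formyl in place of the fluoro of compound 2 on an aromatic carbon, para to a large group (formyl in place of fluoro on an aromatic carbon). Among the measured compounds shown here, no measured step yet shows what this swap does, so only a modest shift is expected. The expected step of a 1.4-fold lower number from compound 2 to compound 3 (0.14 log units; within the scatter) is small, leaning towards a lower number and not beyond the scatter. For compound 3 the estimated value is 16000 nM (expected range from 6000 nM to 40000 nM).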

Compound 3, half-maximal inhibitory concentration: > 100000 nM
Compound 3: a limit, no number; the forecaster's own chance of this, stated with the estimate: 5%; middle value at least 6.2-fold (0.79 log units) away from the limit.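

Placing formyl instead of fluoro on this aromatic carbon, para to a large group, gives the first measured step at this position: in this assay there is an at least 4.5-fold higher number from compound 2 to compound 3 (0.65 log units; beyond the scatter), so the position clearly responds to this change. From the compounds shown here alone, the true size of the step stays unknown, as compound 3 has a limit, not a number: the limit of > 100000 nM in this assay, at which 1 of the 3 values shown sits.

The compounds shown leave open whether this weakening is special to formyl or would also follow an amine or a carboxylic acid here. Going by these compounds, whether any group at this position could give a lower number than fluoro also remains open.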